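Working notes: furan-2-yl for 4-hydroxyphenyl, compound 3

The source may report more compounds than this note shows. Statements on the series, on what has been measured and on what is new or still open speak of the compounds shown alone.

Compound 1 `CC1=CC[C@H](C(C)(C)N=C=S)CC1` and compound 2 `CC1=CC[C@H](C(C)(C)NC(=S)N/N=C/c2ccc(O)cc2)CC1` share the same core. In a functional assay on U-251 cells (Homo sapiens) for inhibition, read by sulforhodamine B assay, with a stated time of 48 h (a higher number here means a weaker inhibitor of growth, a lower number a stronger inhibitor of growth), compound 1 gives only the limit > 100000 nM, not a number. In this assay compound 2 likewise gives only the limit > 100000 nM. Among the compounds with values here, both values sit at the limit of > 100000 nM in this assay, at which 2 of the 2 values shown sit; compound 2 thus stands at the limit, and no measured step between compounds exists in the set.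

Compound 3 `CC1=CC[C@H](C(C)(C)NC(=S)N/N=C/c2ccco2)CC1` differs from compound 2 by furan-2-yl in place of 4-hydroxyphenyl on a carbon with a double bond to nitrogen. Compound 1 and compound 2, both at the limit, give no direction for this change. In this assay the expected step is a number no higher from compound 2 to compound 3 (the limit leaves the size open), none beyond the scatter. Compound 3 is estimated at 100000 nM, with a range from 30000 nM to 300000 nM, and most probably again reported only as a limit.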

Compound 3, concentration for total growth inhibition: 81500 nM
Estimate against measurement, compound 3: 1.2-fold (0.09 log units) above; measured number inside the range.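

In this assay, furan-2-yl in place of 4-hydroxyphenyl on a carbon with a double bond to nitrogen gives an at least 1.2-fold lower number from compound 2 to compound 3 (0.08 log units; that floor lies within the scatter). Compound 3 carries a number where the two earlier compounds carry only limits, so this position admits a change that brings a compound off the limit, here with a five-membered aromatic ring and without the hydrogen-bond donor of 4-hydroxyphenyl. The true size of the step stays unknown, and only a floor can be read, because compound 2 stands at a limit: the limit of > 100000 nM in this assay, at which 2 of the 3 values shown sit.

The compounds shown do not separate the change of ring from the loss of the hydroxyl, and plain phenyl or thiophen-2-yl at this place would bear on that. As far as these compounds go, whether pyridin-2-yl or an aminophenyl would give a lower number than compound 3 also remains open.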